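Diethylamino in place of methoxyethylamino on the shared core

The source may report more compounds than this note shows. Statements on the series, on what has been measured and on what is new or still open speak of the compounds shown alone.

Measured so far:
compound 1, `COCCNc1nc(C)nc2c(-c3c(C)cc(N(C)C)nc3C)c(C)nn12`: > 10000 nM
compound 2, `CCC(CC)Nc1nc(C)nc2c(-c3cnc(OC)cc3C)c(C)nn12`: 3 nM

In an assay on cell membranes for displacement of a labelled ligand from corticotropin-releasing factor receptor 1 (Rattus norvegicus) (a higher number here means a weaker inhibitor, a lower number a stronger inhibitor), compound 1 gives > 10000 nM; this is a limit of the assay and not a number, so compound 1 stands only at the weak edge of the readings shown (the limit of > 10000 nM in this assay, at which 1 of the 2 values shown sits). Within the data shown here, compound 2 gives 3 nM in this assay, and since it differs from compound 1 in more than one place, no single step between the two is drawn.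

The unmeasured compound 3, `CCN(CC)c1nc(C)nc2c(-c3c(C)cc(N(C)C)nc3C)c(C)nn12`, differs from compound 1 in one place: diethylamino in place of (2-methoxyethyl)amino on an aromatic carbon.

Among the measured compounds shown here, no measured step covers this change, so its size has to be guessed. The expectation is a move towards stronger inhibition, the step from compound 1 to compound 3 estimated as an at least 5.0-fold lower number from compound 1 to compound 3 (0.69 log units; beyond the scatter), though with a fair chance that this assay again reports only a limit. For compound 3 the estimated value in this assay is 2000 nM, with a range from 300 nM to 10000 nM.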

Compound 3, half-maximal inhibitory concentration: 58 nM
For compound 3 the middle estimate is 34-fold (1.54 log units) above the measured one; measured number outside the range, below it.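

In this assay, the exchange of (2-methoxyethyl)amino for diethylamino on an aromatic carbon between two ring nitrogen atoms gives an at least 170-fold lower number from compound 1 to compound 3 (2.23 log units; beyond the scatter), so this single place on the shared core is enough to move the series from the edge of the assay to a measurable reading, with the rest of compound 1 unchanged. Compound 1 gives > 10000 nM, which is a limit of the assay and not a number. The step is therefore a lower bound with its true size unknown, because compound 1 stands at that limit: the limit of > 10000 nM in this assay, at which 1 of the 3 values shown sits.

The change removes the ether oxygen and the amine hydrogen together (1 hydrogen-bond donor leaves, 0 enter), and the compounds shown do not tell which of these, or the added carbon, accounts for the step. Ethyl(2-methoxyethyl)amino, which keeps the ether oxygen without the amine hydrogen, and a plain ethylamino or dipropylamino group would divide the change, while whether the step holds on other aryl groups also remains open, as compound 2 differs from both other compounds in more than one place.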